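Aryl Sulfonamides Without Measurable Malate Dehydrogenase Inhibition

The source may report more compounds than this note shows. Statements on the series, on what has been measured and on what is new or still open speak of the compounds shown alone.

compound 1, `O=S(=O)(Nc1ccc2oc(-c3ccccc3)nc2c1)c1cccs1`: > 63000 nM
compound 2, `O=S(=O)(Nc1ccc(-c2nc3ccccc3o2)cc1)c1ccc(Cl)c(C(F)(F)F)c1`: > 63000 nM
compound 3, `O=S(=O)(Nc1ccc(-c2nc3ccccc3o2)cc1)c1ccc(F)cc1`: > 63000 nM

Three sulfonamides have been tested in an assay on isolated protein for inhibition of malate dehydrogenase, mitochondrial (Sus scrofa), with stated times of 45 min and 30 min; a lower number here means a stronger inhibitor, a higher number a weaker inhibitor. For compound 1 the result is only a limit of the assay, > 63000 nM. Compound 2 also gives only a limit of the assay, > 63000 nM. Compound 3 likewise gives only a limit of the assay, > 63000 nM. Compound 1 therefore stands nowhere distinct among the numbers shown: every value is a limit, and (the limit of > 63000 nM in this assay, at which 3 of the 3 values shown sit), so none of the three can be ordered against another, and no step between measured compounds exists.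

Compound 4, `O=S(=O)(Nc1ccc2oc(-c3ccccc3)nc2c1)c1ccc(Cl)cc1`, has not yet been measured. It differs from compound 1 in one place: 4-chlorophenyl in place of thiophen-2-yl on a sulfonyl sulfur. Among the compounds with values here, with no measured step available to guide the expectation, the only basis is the limit of > 63000 nM in this assay, at which 3 of the 3 values shown sit, which points to compound 1 as unmeasurably weak. The step that the limit leaves unreadable from compound 1 to compound 4 is therefore expected to be none beyond the scatter, and the most likely outcome in this assay is again a limit rather than a number. Compound 4 is expected to give about 80000 nM in this assay, with a range from 20000 nM to 300000 nM.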

Compound 4, half-maximal inhibitory concentration: > 63000 nM
Compound 4 gave a limit, no number (the forecaster's own chance of this, stated with the estimate: 85%); the middle value lies beyond the limit too.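

In this assay compound 1 and compound 4 both give only a limit of the assay, so no step can be read for 4-chlorophenyl in place of thiophen-2-yl on a sulfonyl sulfur: the limit of > 63000 nM in this assay, at which 4 of the 4 values shown sit. With no number among them, the compounds shown leave open whether any change to these sulfonamides would bring measurable inhibition.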